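Swapping the Phenyl Group on a Second Core

The compounds below may be only part of what the source reports. "The series", "measured", "known", "first", "only" and "open" are said of these compounds alone.

Measured compounds:
Compound 1 `CNC(=O)c1cc(Oc2ccc(NC(=O)c3nn(-c4ccccc4C(F)(F)F)c(=O)cc3C)cc2F)ccn1` gives 35700 nM in a functional assay on MCF7 cells (Homo sapiens) for cytotoxicity, read by MTT assay, with a stated time of 72 h; a lower number here means a stronger inhibitor, a higher number a weaker inhibitor.
Compound 2 `CNC(=O)c1cc(Oc2ccc(NC(=O)c3nn(-c4ccc(Br)cc4F)c(=O)cc3C)cc2F)ccn1` gives 9360 nM in this assay.
Compound 3 `Cc1cc(=O)n(-c2ccccc2C(F)(F)F)nc1C(=O)Nc1ccc(Oc2ncnc3sccc23)cc1` gives only a limit of this assay, > 40000 nM.

Compounds 1 and 2 share a core and differ in one place only: 4-bromo-2-fluorophenyl in place of 2-(trifluoromethyl)phenyl on an aromatic nitrogen. That single change made a measurable step, a 3.8-fold lower number from compound 1 to compound 2 (0.58 log units; beyond the scatter), so on this core the 4-bromo-2-fluorophenyl group goes with a lower number than the 2-(trifluoromethyl)phenyl group.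

Compound 3 carries the same 2-(trifluoromethyl)phenyl group on a different core; how its core differs from that of compound 1 is not broken down here. Compound 3 sits at the limit of the assay, (the limit of > 40000 nM in this assay, at which 1 of the 3 values shown sits), so its true number is not known, only that it lies at or past that edge.

Compound 4 `Cc1cc(=O)n(-c2ccc(Br)cc2F)nc1C(=O)Nc1ccc(Oc2ncnc3sccc23)cc1` is not yet measured. It relates to compound 3 exactly as compound 2 relates to compound 1: 4-bromo-2-fluorophenyl in place of 2-(trifluoromethyl)phenyl on an aromatic nitrogen. The place of the change is described in the same words in both cases, so this is the same change on a second core.

If the change behaves as it did between compounds 1 and 2, the step from compound 3 to compound 4 is expected to be of a similar size, an at least 2.0-fold lower number from compound 3 to compound 4 (0.30 log units; that floor lies within the scatter), though it starts from a limit rather than a number. Compound 4 is therefore estimated at about 20000 nM, within roughly 8000 nM to 60000 nM.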

Compound 4, half-maximal inhibitory concentration: 15200 nM
For compound 4 the middle estimate is 1.3-fold (0.12 log units) above the measured one, within the range that was stated.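

In this assay the swap of the 2-(trifluoromethyl)phenyl group for the 4-bromo-2-fluorophenyl group goes with a lower number on the second core as well, with an at least 2.6-fold lower number from compound 3 to compound 4 (0.42 log units; beyond the scatter) as the new step. The direction of the change therefore carried over from one core to the other in these two pairs, and the two steps can be set side by side: the same change on two cores in this assay, a 3.8-fold lower number (0.58 log units; beyond the scatter) from compound 1 to compound 2 and an at least 2.6-fold lower number (0.42 log units; beyond the scatter) from compound 3 to compound 4; the limit leaves it open whether they differ. As far as these compounds go, what this does not show is whether the size of the step carried over as well, and the true number for compound 3 remains unknown, as its value is a limit of the assay: the limit of > 40000 nM in this assay, at which 1 of the 4 values shown sits.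

With only two pairs, the compounds shown cannot say whether a third core would follow the same direction, or whether the bromine, the fluorine or the two together go with the lower number. A simple 4-bromophenyl or 2-fluorophenyl group on the same aromatic nitrogen could begin to separate those two atoms, while a phenyl group carrying an amine or a carboxylic acid would test how far the change can be taken beyond halogens.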